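Sulfonamide-benzylamide series: a methyl for fluoro on the amide ring

The source may report more compounds than this note shows. Statements on the series, on what has been measured and on what is new or still open speak of the compounds shown alone.

Measured so far in a functional assay on the whole organism for inhibition, with Mus musculus as the target, with stated times of 30 min and 2 h, at a dose of 10 mg/kg by the intraperitoneal route; a lower number here means less inhibition, a higher number more inhibition at the dose given (going by the name of the read-out):
Compound 1 `Cc1ccc(S(=O)(=O)NCc2ccc(CNC(=O)c3ccc(F)cc3)cc2)cc1` gives 75%.
Compound 2 `O=C(NCc1ccc(CNS(=O)(=O)c2ccccc2)cc1)c1ccc(F)cc1` gives 40%.
Compound 3 `Cc1ccc(S(=O)(=O)NCc2ccc(CNC(=O)c3ccc(Cl)cc3)cc2)cc1` gives 50%.

Compound 2 holds the lowest of the three numbers. Against compound 3 the gap is within the scatter; against compound 1 it is beyond it, the step being a number 35 percentage points lower from compound 1 to compound 2 (beyond the scatter).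

Compound 4 `Cc1ccccc1C(=O)NCc1ccc(CNS(=O)(=O)c2ccccc2)cc1` differs from compound 2 in one place: 2-methylphenyl in place of 4-fluorophenyl on a carbonyl carbon. Going by the values given here, no measured pair changes this ring in the same way. Among the compounds with values here, the only step touching this ring is a number 25 percentage points lower from compound 1 to compound 3 (beyond the scatter), which points downward; the step at the other ring, a number 35 percentage points lower from compound 1 to compound 2 (beyond the scatter), does not bear on the carbonyl-bound ring. Within the data shown here, with one downward step on the amide ring and no methyl precedent at all, the expectation for compound 4 is a step of uncertain direction, most likely within the scatter, a number 5 percentage points lower from compound 2 to compound 4 (within the scatter). Compound 4 is therefore estimated at 35% in this assay, within the range 10% to 60%.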

Compound 4, a percentage reported as inhibition, in the whole organism at one dose (the size of the read-out at that dose, not a potency): "not active" (no number reported)
Compound 4: no number reported; the estimate stays without a comparison.
By their numbers in this assay, from the lowest: compounds 2 and 3 (each within the scatter of the next); then compound 1.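

Going by these compounds alone, compound 4 is reported as not active, with no number, in this assay; no step from compound 2 to compound 4 can be read. The compounds shown leave open the size of the change from 4-fluorophenyl to 2-methylphenyl on a carbonyl carbon. No supporting measurement bears on this result.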